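The compounds below may be only part of what the source reports. "The series", "measured", "known", "first", "only" and "open" are said of these compounds alone.

Measured compounds:
Compound 1 `Cn1cccc1-c1ncnc2c1ncn2C1O[C@H](CO)[C@@H](O)[C@H]1O`: 2000 nM
Compound 2 `Cc1cc(-c2ncnc3c2ncn3C2O[C@H](CO)[C@@H](O)[C@H]2O)on1`: "not active" (no number reported)
Compound 3 `OC[C@H]1OC(n2cnc3c(-c4nccs4)ncnc32)[C@H](O)[C@@H]1O`: 2730 nM

All three share one core carrying a five-membered aromatic ring, and all were tested in a functional assay on CCRF-CEM cells (Homo sapiens) for inhibition; a higher number here means a weaker inhibitor, a lower number a stronger inhibitor. Of the two compounds that gave a number, compound 1 stands lowest; its nearest neighbour is compound 3, and the step of a 1.4-fold higher number from compound 1 to compound 3 (0.14 log units; within the scatter). Compound 2 gave no number in this assay and is reported simply as not active.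

The unmeasured compound 4 `OC[C@H]1OC(n2cnc3c(-c4cc[nH]c4)ncnc32)[C@H](O)[C@@H]1O` differs from compound 1 in one place: 1H-pyrrol-3-yl in place of 1-methyl-1H-pyrrol-2-yl on an aromatic carbon. Going by the values given here, the only measured step that bears on this change is the one from compound 1 to compound 3, which also swaps the five-membered ring on the same carbon and which stayed within the scatter. No measured pair covers a ring that carries a hydrogen-bond donor in place of one with a hydrogen-bond acceptor, so that part of the change has no precedent among these compounds. The result for compound 2 shows that a ring swap at this position can also remove measurable activity, which widens the range.

On this basis the step of a 1.4-fold higher number from compound 1 to compound 4 (0.15 log units; within the scatter) is expected to stay small. Compound 4 is therefore estimated at 2800 nM, with a range from 1000 nM to 8000 nM in this assay.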

Compound 4, half-maximal inhibitory concentration: 1030 nM
For compound 4 the middle estimate is 2.7-fold (0.43 log units) above the measured one, within the range that was stated.
By their numbers in this assay, from the lowest: compounds 4, 1 and 3 (each within the scatter of the next, the first and the last beyond it).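

In this assay, going by these compounds alone, the 1H-pyrrol-3-yl group of compound 4 gives the first step at this position that lies beyond the scatter, though only a modest one: a 2.7-fold lower number from compound 3 to compound 4 (0.42 log units; beyond the scatter), with 1H-pyrrol-3-yl in place of 1,3-thiazol-2-yl on the same aromatic carbon. Against the 1-methyl-1H-pyrrol-2-yl group the outcome is different, since a 1.9-fold lower number from compound 1 to compound 4 (0.29 log units; within the scatter) stays within the scatter, so the hydrogen-bond donor that enters with the new ring does not separate these two compounds, and the earlier lack of any precedent for such a donor at this carbon is now filled by this one case. Nothing at hand accounts for either step.

The change from compound 1 to compound 4 alters the point of attachment and removes the methyl group in a single step, so the compounds shown cannot tell these two parts apart; 1H-pyrrol-2-yl and 1-methyl-1H-pyrrol-3-yl groups would separate them. Going by these compounds, how a six-membered ring such as phenyl or pyridin-3-yl, or an amine on this carbon, would compare also remains open.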